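A few compounds are considered here, and "the series" means these few. Any claim that something is new, unique, unknown or untested is made for them only; others in the source may bear on it.

In an ADME assay on MDCK cells (Canis lupus familiaris) for cytotoxicity (a higher number here means that more compound is tolerated, a lower number that less compound is tolerated), compound 1 `CC1(C)C[C@H](O)C[C@](C)(CNC(=O)c2cc(Cl)ccc2O)C1` gives > 50000 nM, which is a limit of the assay and not a number. Compound 2 `CN(C(=O)C1(c2ccccc2)CCCC1)C1CCCCC1` gives 21000 nM. Compound 3 `CN(C(=O)C1(c2ccccc2)CCCC1)c1ccccc1Cl` gives 23000 nM, so the two measured numbers stand level. Going by the values given here, the one measured step that bears on what follows is a 1.1-fold higher number from compound 2 to compound 3 (0.04 log units; within the scatter), with 2-chlorophenyl in place of cyclohexyl on an amide-type nitrogen. Compound 4 `CN(C(=O)C1(c2ccccc2)CCCC1)c1ccc(Cl)cc1` differs from compound 3 at that same nitrogen: 4-chlorophenyl in place of 2-chlorophenyl on an amide-type nitrogen. Among the compounds with values here, with only that small step as a guide, no change beyond the scatter is expected in this assay. The expected step is a 1.0-fold lower number from compound 3 to compound 4 (0.02 log units; within the scatter). For compound 4 the estimated value is 22000 nM, with an expected range of 10000 nM to 45000 nM.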

Compound 4, half-maximal cytotoxic concentration: 20000 nM
Compound 4: middle estimate off by 1.1-fold (0.04 log units), on the high side, and the stated range covers the measured number.
By their numbers in this assay, from the lowest: compounds 4, 2 and 3 (each within the scatter of the next). At a limit, above all of these: compound 1.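

On the amide-type nitrogen, 4-chlorophenyl in place of 2-chlorophenyl gives a 1.2-fold lower number from compound 3 to compound 4 (0.06 log units; within the scatter) in this assay, so where the chlorine sits on that phenyl ring makes no readable difference among these compounds. Against cyclohexyl the reading is the same, with a 1.1-fold lower number from compound 2 to compound 4 (0.02 log units; within the scatter), so all three groups on that nitrogen stand level. Nothing on record explains this result. From the compounds shown here alone, it remains open whether a phenyl ring carrying an amine or a carboxylic acid on that nitrogen would give a step beyond the scatter. The same holds for a simple methyl group there.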